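Solubility notes on the shared amide core

The source may report more compounds than this note shows. Statements on the series, on what has been measured and on what is new or still open speak of the compounds shown alone.

Measured in a physicochemical assay for solubility; a lower number here means a less soluble compound, a higher number a more soluble compound:
- compound 1 `CNC(=O)c1cc(C(=O)NCCC2CCOCC2)cn(Cc2ccccc2)c1=O` gives >= 127 ug/mL, a limit of the assay.
- compound 2 `CNC(=O)c1cc(C(=O)NC2CC2)cn(CC2CCCCC2)c1=O` gives >= 148 ug/mL, a limit of the assay.
- compound 3 `CNC(=O)c1cc(C(=O)NC2CC2)cn(Cc2cccc(C#N)c2)c1=O` gives >= 148 ug/mL, a limit of the assay.

Compound 1 stands only at a limit in this assay; no number is known for it, and the two further values shown are limits as well (the limit of >= 127 ug/mL in this assay, at which 1 of the 3 values shown sits, (the limit of >= 148 ug/mL in this assay, at which 2 of the 3 values shown sit)). Among the compounds with values here, the single step between measured compounds that differ in one place, a step that the two limits leave unreadable from compound 2 to compound 3, is left unreadable by the two limits, so no size is available from it.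

Compound 4 `CNC(=O)c1cc(C(=O)NCCOC)cn(Cc2ccccc2)c1=O` differs from compound 1 by methoxy in place of oxan-4-yl on a saturated chain carbon, two bonds along the chain from an amide-type nitrogen. Within the data shown here, no measured step bears on a change of this kind at a saturated chain carbon two bonds along the chain from an amide-type nitrogen; the only measured step sits on the saturated chain carbon bound to the aromatic nitrogen and gives no size. The expectation therefore rests on compound 1 standing at its limit, with nothing shown that points downward.

In this assay compound 4 is expected to give 150 ug/mL, within 90 ug/mL to 300 ug/mL. The step that the limit leaves unreadable from compound 1 to compound 4 is expected to stay within the scatter, and the assay is expected most likely to report only a limit again.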

Compound 4, solubility: >= 164 ug/mL
Compound 4 gave a limit, no number (the forecaster's own chance of this, stated with the estimate: 80%); middle value at least 1.0-fold (0.03 log units) from the limit.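

In this assay compound 4 gives >= 164 ug/mL, a limit of the assay. Compound 1 also stands only at a limit, so no step can be read between compound 1 and compound 4. The compounds shown leave open where any of the four true solubility values lies, and what size, if any, methoxy in place of oxan-4-yl has.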